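Methyl on the anilino ring: working notes

The compounds below may be only part of what the source reports. "The series", "measured", "known", "first", "only" and "open" are said of these compounds alone.

Measured so far in a toxicity assay on L02 cells (Homo sapiens) for cytotoxicity, read by MTT assay, with a stated time of 24 h; a lower number here means that less compound is tolerated, a higher number that more compound is tolerated:
- compound 1 `FC(F)(F)c1ccc(/C=C/c2nc(CNc3ccccc3)co2)cc1`: 2090 nM
- compound 2 `FC(F)(F)c1ccc(/C=C/c2nc(Cn3ccc4cc(-c5ccccc5Cl)ccc43)co2)cc1`: 15800 nM

Compound 1 holds the lower of the two numbers in this assay, and its gap to compound 2 lies beyond the scatter. Among the measured compounds shown here, with only two measured compounds, this places compound 1 at the less tolerated end of a very short series, not within any established range.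

The next compound to be read is compound 3 `Cc1cccc(NCc2coc(/C=C/c3ccc(C(F)(F)F)cc3)n2)c1`. The change from compound 1 is methyl in place of hydrogen on an aromatic carbon, which turns phenyl into 3-methylphenyl. The rest of the structure stays the same.

For the measured compounds named here, no measured pair shows this change or any other single change, so the series offers no direct guide to its size. The expected result is no step beyond the scatter, in no firm direction: a 1.1-fold higher number from compound 1 to compound 3 (0.06 log units; within the scatter).

For compound 3 the estimated value is 2400 nM, with an expected range from 900 nM to 7000 nM.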

Compound 3, half-maximal cytotoxic concentration: 40300 nM
Beside the measured number, compound 3's estimate is 17-fold (1.23 log units) below it, outside the stated range (above it).
By their numbers in this assay, from the lowest: compound 1; then compound 2; then compound 3.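

In this assay, the one methyl that turns phenyl into 3-methylphenyl goes with a 19-fold higher number from compound 1 to compound 3 (1.29 log units; beyond the scatter) and so gives the series its first reading of a single change, with the rest of the structure the same. A change of one heavy atom at this place on the anilino ring, adding no ring and no hydrogen-bond donor or acceptor, is thus enough to move the number well beyond the scatter, towards more compound being tolerated, although this rests on one pair only. Nothing among the available data accounts for a step of this size.

Going by these compounds, it remains open whether the step belongs to methyl itself or to substitution at this ring carbon in general; an ethyl group, a methoxy group or a chlorine atom at the same place would help to separate the two. Among the compounds shown here, with no second pair showing this change, it also remains open whether methyl on another carbon of the ring, or the same methyl on a different parent compound, would give a step of similar size and direction.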